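A few compounds are considered here, and "the series" means these few. Any claim that something is new, unique, unknown or untested is made for them only; others in the source may bear on it.

The series shares the core of compound 1 `CC/C(=C(/c1ccc(/C=C/C(=O)O)cc1)c1ccc2[nH]ncc2n1)c1ccccc1` and varies the bicyclic group on a double-bonded chain carbon bound to an aromatic carbon and a double-bonded chain carbon. In a functional assay on MCF7 cells (Homo sapiens) for cytotoxicity, read by CellTiter-Glo, with a stated time of 5 days (a higher number here means a weaker inhibitor, a lower number a stronger inhibitor), compound 1 gives 33 nM. Compound 2 `CC/C(=C(/c1ccc(/C=C/C(=O)O)cc1)c1ccc2[nH]nc(C)c2c1)c1ccccc1` carries 3-methyl-1H-indazol-5-yl; in this assay compound 2 reaches the limit > 1000 nM, a limit of the assay and not a number (the limit of > 1000 nM in this assay, at which 1 of the 3 values shown sits). Compound 3 `CC/C(=C(/c1ccc(/C=C/C(=O)O)cc1)c1cc2cn[nH]c2cc1F)c1ccccc1` carries 6-fluoro-1H-indazol-5-yl and in this assay gives 47 nM, the higher of the two numbers available, although a 1.4-fold higher number from compound 1 to compound 3 (0.15 log units; within the scatter) keeps it within the scatter of compound 1. Compound 4 `CC/C(=C(/c1ccc(/C=C/C(=O)O)cc1)c1ccc2[nH]nc(Cl)c2c1)c1ccccc1` is the next member: 3-chloro-1H-indazol-5-yl in place of 6-fluoro-1H-indazol-5-yl on a double-bonded chain carbon bound to an aromatic carbon and a double-bonded chain carbon. The step that bears on it is an at least 21-fold lower number from compound 2 to compound 3 (1.32 log units; beyond the scatter), a large step, together with an at least 30-fold higher number from compound 1 to compound 2 (1.48 log units; beyond the scatter); the entering 3-chloro-1H-indazol-5-yl stands close to the 3-methyl-1H-indazol-5-yl of compound 2, so the change runs that comparison in reverse. A large step upward, back toward the limit, is therefore expected: a 17-fold higher number from compound 3 to compound 4 (1.23 log units; beyond the scatter). Compound 4 is estimated at 800 nM, with a range from 150 nM to 4000 nM.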

Compound 4, half-maximal inhibitory concentration: 284 nM
Estimate against measurement, compound 4: 2.8-fold (0.45 log units) above; the range from low to high includes it.
By their numbers in this assay, from the lowest: compounds 1 and 3 (each within the scatter of the next); then compound 4. At a limit, above all of these: compound 2.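

The change of chloro in place of methyl on an aromatic carbon brings back part of what compound 2 gave up in this assay: an at least 3.5-fold lower number from compound 2 to compound 4 (0.54 log units; beyond the scatter). Compound 2 remains at a limit of the assay and not at a number, so that step gives only a bound: the limit of > 1000 nM in this assay, at which 1 of the 4 values shown sits.

The recovery is partial, with a 6.0-fold higher number from compound 3 to compound 4 (0.78 log units; beyond the scatter) and an 8.6-fold higher number from compound 1 to compound 4 (0.93 log units; beyond the scatter), so among the compounds shown, both groups substituted at the 3-position of the 1H-indazol-5-yl stand above compounds 1 and 3.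

With only methyl and chloro shown there, it remains open how far the outcome depends on the group itself, and how a nitrile, an amine or a methoxy group would fare in that place. Also open, as far as these compounds go, is whether 3-fluoro-1H-indazol-5-yl would stay with compounds 1 and 3 or move toward compound 4.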